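Swapping the Aryl Group on an Amide Nitrogen

The compounds below may be only part of what the source reports. "The series", "measured", "known", "first", "only" and "open" are said of these compounds alone.

Measured so far:
compound 1 `CO[C@@H]1CC=C2NN(c3ccc(C)cc3)C(=O)CC[C@]2(c2ccccc2)O1`: 3170 nM
compound 2 `CO[C@@H]1CC=C2N(c3ccc(C)cc3)C(=O)C[C@]2(c2ccccc2)O1`: 3920 nM

In a functional assay on A549 cells (Homo sapiens) for cytotoxicity, read by sulforhodamine B assay, with a stated time of 48 h (a lower number here means a stronger inhibitor, a higher number a weaker inhibitor), compound 2 gives 3920 nM, the higher of the two numbers, yet the gap to compound 1, which gives 3170 nM, lies within the scatter, so the two cannot be told apart. Compound 3 `CO[C@@H]1CC=C2N(c3cc(Cl)cc(Cl)c3)C(=O)C[C@]2(c2ccccc2)O1` differs from compound 2 in one place: 3,5-dichlorophenyl in place of 4-methylphenyl on an amide-type nitrogen in a ring. Among the measured compounds shown here, no measured pair shows this change, so there is nothing to lean on; a modest lowering of the number, barely beyond the scatter, is expected: a 1.6-fold lower number from compound 2 to compound 3 (0.20 log units; within the scatter). Compound 3 is expected to give about 2500 nM, within a range of 800 nM to 8000 nM.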

Compound 3, half-maximal inhibitory concentration: 7530 nM
Compound 3: the middle estimate sits 3.0-fold (0.48 log units) below what was measured, and the stated range covers the measured number.
By their numbers in this assay, from the lowest: compounds 1, 2 and 3 (each within the scatter of the next, the first and the last beyond it).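

In this assay, replacing 4-methylphenyl with 3,5-dichlorophenyl on the amide-type nitrogen gives a 1.9-fold higher number from compound 2 to compound 3 (0.28 log units; within the scatter) and so no difference that can be read. Among the compounds shown here, this is the first direct look at this position, and these two quite differently substituted aryl groups cannot be told apart there. Nothing available bears on why the numbers fall as they do.

Only these two aryl groups have been compared at this nitrogen. As far as these compounds go, whether an amine or a carboxylic acid on the phenyl ring, or a plain alkyl chain in its place, would shift the number beyond the scatter remains open.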